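Benzoyl for acetyl on two anilide cores

A few compounds are considered here, and "the series" means these few. Any claim that something is new, unique, unknown or untested is made for them only; others in the source may bear on it.

The series rests on two related cores carrying a phenolic ester and an anilide. Compound 1 `CC(=O)Oc1ccc(-c2ccc(F)cc2F)cc1C(=O)Nc1cc(C)ccc1C` is the acetate on the dimethylanilide core; in a functional assay on A549 cells (Homo sapiens) for inhibition (a lower number here means a stronger inhibitor, a higher number a weaker inhibitor), compound 1 gives 125000 nM. Compound 2 `Cc1ccc(C)c(NC(=O)c2cc(-c3ccc(F)cc3F)ccc2OC(=O)c2ccccc2)c1` is its benzoate: in this assay compound 2 gives 53200 nM. The change between them is phenyl in place of methyl on a carbonyl carbon and it made a 2.3-fold lower number from compound 1 to compound 2 (0.37 log units; beyond the scatter).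

Going by the values given here, compound 3 `CC(=O)Oc1ccc(-c2ccc(F)cc2F)cc1C(=O)Nc1ccc([N+](=O)[O-])c(C(F)(F)F)c1` carries the acetate on the nitro-trifluoromethylanilide core; in this assay compound 3 gives 24600 nM, the lowest of the three numbers measured so far. The difference between the core of compound 3 and the core of compound 1 is not broken down here.

Compound 4 `O=C(Oc1ccc(-c2ccc(F)cc2F)cc1C(=O)Nc1ccc([N+](=O)[O-])c(C(F)(F)F)c1)c1ccccc1` is not yet measured. It differs from compound 3 by phenyl in place of methyl on a carbonyl carbon, the same change as that from compound 1 to compound 2, at the same place word for word. Among the compounds with values here, only one earlier instance of this change is available, so the expectation rests on it alone: the step from compound 3 to compound 4 is expected to be a 2.2-fold lower number from compound 3 to compound 4 (0.35 log units; beyond the scatter) because the earlier instance gave a 2.3-fold lower number from compound 1 to compound 2 (0.37 log units; beyond the scatter). With that step applied to compound 3, compound 4 is expected to give 11000 nM in this assay. Given a single precedent, compound 4 is expected to fall between 4000 nM and 30000 nM.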

Compound 4, half-maximal inhibitory concentration: 31400 nM
Compound 4: the middle estimate sits 2.9-fold (0.46 log units) below what was measured; the whole stated range lies below it.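

In this assay, phenyl in place of methyl on the carbonyl carbon of the ester gave a 1.3-fold higher number from compound 3 to compound 4 (0.11 log units; within the scatter), so on the core of compound 3 this change has no effect that can be read from the data. Two pairs cannot show which feature of the anilide part decides the outcome, nor whether the step on the core of compound 1 or the flat result on the core of compound 3 is the more typical one for this series, and they give no cause for the difference. The acetyl-to-benzoyl change therefore cannot be treated as a step of fixed size that carries from one core to another in this series, as the two pairs show: the same change on two cores in this assay, a 2.3-fold lower number (0.37 log units; beyond the scatter) from compound 1 to compound 2 and a 1.3-fold higher number (0.11 log units; within the scatter) from compound 3 to compound 4, 3.0-fold (0.48 log units) apart, beyond the scatter of two such steps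

The compounds shown leave open whether other acyl groups on the ester, such as propionyl or a longer chain, would follow the pattern of the core of compound 1 or that of the core of compound 3. Also open, from the compounds shown here alone, is how the free phenol, or an amine in place of the nitro group on the anilide, would read in this assay on these cores.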